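This account rests on a few compounds, and the source may have more. Where it says the series, first, only, none or still open, it means among the compounds named here.

In a functional assay on A549 cells (Homo sapiens) for inhibition, read by sulforhodamine B assay (a lower number here means a stronger inhibitor, a higher number a weaker inhibitor), compound 1 `COC(=O)CC/C(C)=C/Cc1c(OC)c(C)c2c(c1OCC#CCN1CCN(c3ccccc3F)CC1)C(=O)OC2` gives 45300 nM. Compound 2 `COC(=O)CC/C(C)=C/Cc1c(OC)c(C)c2c(c1OCC#CCN1CCN(Cc3ccc(Cl)cc3)CC1)C(=O)OC2` reads > 50000 nM, which is a limit of the assay and not a number. Compound 3 `COC(=O)CC/C(C)=C/Cc1c(OC)c(C)c2c(c1OCC#CCN1CCN(c3ccccc3OC)CC1)C(=O)OC2` carries 2-methoxyphenyl in place of 4-chlorobenzyl on an amine nitrogen in a ring. For the measured compounds named here, the one measured step bearing on this site, an at least 1.1-fold higher number from compound 1 to compound 2 (0.04 log units; that floor lies within the scatter), put 4-chlorobenzyl in place of 2-fluorophenyl and stays within the scatter. So no step beyond the scatter is expected in this assay, and the estimated change is an at least 1.2-fold lower number from compound 2 to compound 3 (0.09 log units; that floor lies within the scatter). Compound 3 is expected at 40000 nM, within an estimated range of 20000 nM to 50000 nM.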

Compound 3, half-maximal inhibitory concentration: > 50000 nM
Compound 3: a limit, no number; the forecaster's own chance of this, stated with the estimate: 50%; middle value at least 1.2-fold (0.09 log units) away from the limit.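

In this assay, methoxy in place of fluoro on an aromatic carbon gives an at least 1.1-fold higher number from compound 1 to compound 3 (0.04 log units; that floor lies within the scatter), so only a floor can be read for this change at the site. The step between compound 2 and compound 3 cannot be read because both readings are limits: the limit of > 50000 nM in this assay, at which 2 of the 3 values shown sit.

From the compounds shown here alone, the true size of the gap from compound 1 to compound 3 stays open. Also open, going by these compounds, is whether a carboxylic acid or an amine on this amine nitrogen in place of these aromatic groups would give a reading clear of the limit.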